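Notes on a ring swap at the thioether sulfur

The source may hold more compounds than are shown below. What is called first, only, known or untested is meant among the compounds shown, and "the series" means these compounds.

Measured in a functional assay on MCF7 cells (Homo sapiens) for cytotoxicity, read by MTT assay, with a stated time of 24 h, tested at 16 ug/mL; on this read-out higher numbers stand for a stronger effect at the one concentration tested and lower numbers for a weaker effect:
compound 1 `Cc1ccc2oc(SCC(=O)Nc3ccc(-c4nc(-c5ccccc5)c(-c5ccccc5)n4C)cc3)nc2c1`: 40.3%
compound 2 `Cc1nnc(SCC(=O)Nc2ccc(-c3nc(-c4ccccc4)c(-c4ccccc4)n3C)cc2)s1`: 74.9%

Compound 2 stands highest of the two numbers, with compound 1 nearest and lower by a number 34.6 percentage points higher from compound 1 to compound 2 (beyond the scatter). Compound 3 `Cn1c(-c2ccc(NC(=O)CSC3=NCCS3)cc2)nc(-c2ccccc2)c1-c1ccccc1` is not yet measured. It carries a group of 5 heavy atoms (3 carbon, 1 nitrogen, 1 sulfur; one five-membered non-aromatic ring with 2 hetero atoms) in place of a group of 6 heavy atoms (3 carbon, 2 nitrogen, 1 sulfur; one five-membered aromatic ring with 3 hetero atoms), on a sulfur. Going by the values given here, the only measured step, from compound 1 to compound 2, also exchanged the group on this sulfur and was large; it bears on the present change only loosely, as both groups there were aromatic. A step in this assay of moderate size downward, a number 19.9 percentage points lower from compound 2 to compound 3 (beyond the scatter), is expected. Compound 3 is estimated at 55%, within 30% to 80%.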

Compound 3, a percentage reported as activity, at one concentration (the size of the read-out at that concentration, not a potency): 41.8%
For compound 3 the middle estimate is 13.2 percentage points above the measured one; measured number inside the range.
By their numbers in this assay, from the lowest: compounds 1 and 3 (each within the scatter of the next); then compound 2.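

Replacing the 5-methyl-1,3,4-thiadiazol-2-yl group on the sulfur with the non-aromatic ring in this assay gives a number 33.1 percentage points lower from compound 2 to compound 3 (beyond the scatter) and so the high value of compound 2 does not carry over to this five-membered ring. The other new comparison gives a number 1.5 percentage points higher from compound 1 to compound 3 (within the scatter) even though the two groups differ widely in heavy atoms and ring count, so heavy-atom count alone does not order the three compounds. No measured evidence accounts for either step.

Going by these compounds, it remains open whether the thiadiazole needs its methyl group to keep this value. An open-chain group on the sulfur, such as an ethyl or a carboxylic acid chain, also remains to be placed against these rings.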